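Pyrrolidin-1-yl in place of 3-hydroxypiperidin-1-yl on compound 3

The source may report more compounds than this note shows. Statements on the series, on what has been measured and on what is new or still open speak of the compounds shown alone.

Values in a functional assay on NCI-H460 cells (Homo sapiens) for inhibition, read by sulforhodamine B assay, with a stated time of 72 h; a lower number here means a stronger inhibitor, a higher number a weaker inhibitor
- compound 1 `CC(C)c1cc(-n2cc(-c3ccc(CN4CCN(c5ccccc5)CC4)cc3)nn2)c(O)cc1O` gives > 1000 nM (a limit)
- compound 2 `CC(C)c1cc(-n2nncc2-c2ccc(CN3CCCC(O)C3)cc2)c(O)cc1O` gives 45 nM
- compound 3 `CCNC(=O)c1nnn(-c2cc(C(C)C)c(O)cc2O)c1-c1ccc(CN2CCCC(O)C2)cc1` gives 62 nM

For the measured compounds named here, the one measured step is a 1.4-fold higher number from compound 2 to compound 3 (0.14 log units; within the scatter) and it leaves compound 3 level with its only numerical neighbour. Compound 4 `CCNC(=O)c1nnn(-c2cc(C(C)C)c(O)cc2O)c1-c1ccc(CN2CCCC2)cc1` carries the change pyrrolidin-1-yl in place of 3-hydroxypiperidin-1-yl on a saturated chain carbon bound to an aromatic carbon with pyrrolidin-1-yl in place of 3-hydroxypiperidin-1-yl on a saturated chain carbon bound to an aromatic carbon. Going by the values given here, no measured step isolates a change at this place, and the ethylcarbamoyl step concerns a different one. With compound 3 at 62 nM as the anchor, no shift beyond the scatter is expected in this assay and no direction is favoured. The expected step is a 1.0-fold lower number from compound 3 to compound 4 (0.01 log units; within the scatter) by estimate. The estimate for compound 4 is 60 nM with an expected range from 20 nM to 200 nM as a working figure.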

Compound 4, half-maximal inhibitory concentration: 3 nM
Beside the measured number, compound 4's estimate is 20-fold (1.30 log units) above it; the measured number lies below the stated range.
By their numbers in this assay, from the lowest: compound 4; then compounds 2 and 3 (each within the scatter of the next). At a limit, above all of these: compound 1.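

In this assay, for the compounds shown here, the place on a saturated chain carbon bound to an aromatic carbon turns out to be highly sensitive: pyrrolidin-1-yl in place of 3-hydroxypiperidin-1-yl gives a 21-fold lower number from compound 3 to compound 4 (1.32 log units; beyond the scatter), the first large step. This single step alters ring size and removes the hydroxy group together, so the two changes cannot be separated. Nothing measured here explains the step. Still open, from the compounds shown here alone, is how piperidin-1-yl, morpholin-4-yl or open-chain diethylamino would read at this place. Also open, going by these compounds, is whether pyrrolidin-1-yl gives a similar step without the ethylcarbamoyl group.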